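Moving the Chlorine on a Chlorophenyl Group

The source may hold more compounds than are shown below. What is called first, only, known or untested is meant among the compounds shown, and "the series" means these compounds.

In a functional assay on HeLa cells (Homo sapiens) for antiproliferative activity, read by MTT assay, with a stated time of 48 h (on this read-out higher numbers stand for weaker inhibition and lower numbers for stronger inhibition), compound 1 (`CCn1cc(-c2nc3ccc([N+](=O)[O-])cc3o2)c(=O)c2cc(F)c(N3CCNC(C)C3)c(F)c21`) gives 2980 nM and compound 2 (`CCn1cc(-c2ccc(Cl)cc2)c(=O)c2cc(F)c(N3CCNCC3)cc21`) gives 15400 nM as the higher of the two numbers. Compound 2 thus stands at the weaker end of this pair, and its gap to compound 1 lies beyond the usual scatter. Compound 3 (`CCn1cc(-c2cccc(Cl)c2)c(=O)c2cc(F)c(N3CCNCC3)cc21`) carries 3-chlorophenyl in place of 4-chlorophenyl on an aromatic carbon and otherwise keeps the structure of compound 2. The two measured compounds differ in more than one place, so the data offer no direct guide to how this assay responds to a change of this kind. Compound 2 at 15400 nM is the only close reference, so compound 3 is expected to stay near it, with no step beyond the scatter and no firm direction. The expected change is small (a 1.2-fold lower number from compound 2 to compound 3 (0.07 log units; within the scatter)) and remains an estimate. For compound 3 the estimated value is 13000 nM with an expected range from 5500 nM to 30000 nM in this read-out.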

Compound 3, half-maximal inhibitory concentration: 16100 nM
Estimate against measurement, compound 3: 1.2-fold (0.09 log units) below; the measured number falls inside the stated range.
By their numbers in this assay, from the lowest: compound 1; then compounds 2 and 3 (each within the scatter of the next).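

Within the data shown here, the only single-place comparison in this set is the move from 4-chlorophenyl to 3-chlorophenyl, which gives a 1.0-fold higher number from compound 2 to compound 3 (0.02 log units; within the scatter) in this assay. On the aromatic carbon that carries this group, the read-out therefore does not distinguish the two placements of the chlorine, and compound 2 and compound 3 read alike even though their atoms are joined differently. Nothing available here accounts for this result or shows whether the two compounds behave alike in any other respect.

The compounds shown leave open whether a methoxy group, an amine or a carboxylic acid in place of the chlorine on this phenyl group would also leave the number within the scatter of compound 2. As far as these compounds go, whether exchanging the whole chlorophenyl group for a pyridine ring, or the ethyl group for a longer chain, would separate a compound from compound 2 and compound 3 in this assay also remains open.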